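A few compounds are considered here, and "the series" means these few. Any claim that something is new, unique, unknown or untested is made for them only; others in the source may bear on it.

Measured in a functional assay on MKN-45 cells (Homo sapiens) for antiproliferative activity, read by MTT assay, with a stated time of 72 h, tested at 10 uM; on this read-out higher numbers stand for more inhibition at the one concentration tested (going by the name of the read-out) and lower numbers for less inhibition:

compound 1 `O=C(Nc1cc(Oc2ccc(Nc3nccc4[nH]cc(-c5ccc(F)cc5)c(=O)c34)cc2F)ccn1)C1CCC1`: 52.8%
compound 2 `CCC(=O)Nc1cc(Oc2ccc(Nc3nccc4[nH]cc(-c5ccc(F)cc5)c(=O)c34)cc2F)ccn1`: 92.1%
compound 3 `Nc1nccc(Oc2ccc(Nc3nccc4[nH]cc(-c5ccc(F)cc5)c(=O)c34)cc2F)c1Cl`: 85.7%

Compound 2 stands highest of the three numbers in this assay; compound 3 lies within the scatter of it, compound 1 lies beyond the scatter below it, as a number 39.3 percentage points higher from compound 1 to compound 2 (beyond the scatter) shows.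

The next compound, compound 4 `CC(C)(C)C(=O)Nc1cc(Oc2ccc(Nc3nccc4[nH]cc(-c5ccc(F)cc5)c(=O)c34)cc2F)ccn1`, differs from compound 2 at one place: tert-butyl in place of ethyl on a carbonyl carbon.

Going by the values given here, only one measured step touches this carbonyl carbon: a number 39.3 percentage points higher from compound 1 to compound 2 (beyond the scatter), where a larger group gave way to ethyl and the number rose strongly. The step of a number 6.4 percentage points lower from compound 2 to compound 3 (within the scatter) changes a different part of the molecule and does not bear on this change. Among the compounds with values here, compound 4 puts a larger group back on the same carbon, so on the single step at hand a drop beyond the scatter is expected, though how far a tert-butyl tracks a cyclobutyl is not known from these three compounds.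

Compound 4 is expected to give about 60%, within 40% to 85% in this assay. This amounts to an estimated step of a number 32.1 percentage points lower from compound 2 to compound 4 (beyond the scatter).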

Compound 4, a percentage reported as inhibition, at one concentration (the size of the read-out at that concentration, not a potency): 62.5%
The estimate for compound 4 lay 2.5 percentage points below the measured number; the measured number falls inside the stated range.
By their numbers in this assay, from the lowest: compounds 1 and 4 (each within the scatter of the next); then compounds 3 and 2 (each within the scatter of the next).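

In this assay a second bulky group on this carbonyl carbon also gives a loss, with a number 29.6 percentage points lower from compound 2 to compound 4 (beyond the scatter) in the tert-butyl amide, so the low number of the cyclobutyl amide is not a peculiarity of that one group. With a number 9.7 percentage points higher from compound 1 to compound 4 (within the scatter) the open branched tert-butyl and the ring-bearing cyclobutyl cannot be told apart, and among these three amides only ethyl reaches the high number. Nothing measured on these compounds accounts for the loss.

Going by these compounds, whether methyl or a longer straight chain such as n-butyl on the same carbonyl carbon keeps the number of compound 2 remains open, as does the effect of an amine or methoxy there. Readings at one concentration also leave the potency differences within this amide set unresolved.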